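The source may report more compounds than this note shows. Statements on the series, on what has been measured and on what is new or still open speak of the compounds shown alone.

Compound 1 `CCN1CCN(C[C@H]2CN(c3ccc(-n4cc(-c5ccccn5)cn4)c(F)c3)C(=O)O2)CC1`: in an ADME assay on L02 cells (Homo sapiens) for cytotoxicity, read by MTT assay, with a stated time of 48 h (on this read-out lower numbers stand for stronger inhibition and higher numbers for weaker inhibition), compound 1 gives 99 ug/mL.
Compound 2 `O=C1CCC(=O)N1C[C@H]1CN(c2ccc(-n3cc(-c4ccccn4)cn3)c(F)c2)C(=O)O1`: in this assay compound 2 reaches only a limit of the assay, > 400 ug/mL.
Compound 3 `COC[C@H]1CN(c2ccc(-n3cc(-c4ccccn4)cn3)c(F)c2)C(=O)O1`: in this assay compound 3 reaches only a limit of the assay, > 400 ug/mL.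

All three share one core and differ only in the group on a saturated chain carbon bound to a saturated ring carbon. Compound 3 stands at a limit, so no exact number is known for it; what is known is that its value lies beyond that of compound 1, since an at least 4.0-fold higher number from compound 1 to compound 3 (0.60 log units; beyond the scatter). The same holds for an at least 4.0-fold higher number from compound 1 to compound 2 (0.60 log units; beyond the scatter). Between the two limit compounds the step that the two limits leave unreadable from compound 2 to compound 3 cannot be read, which is a direct consequence of the limit of > 400 ug/mL in this assay, at which 2 of the 3 values shown sit.

Compound 4 `CCC(=O)NC[C@H]1CN(c2ccc(-n3cc(-c4ccccn4)cn3)c(F)c2)C(=O)O1` is the next compound. It differs from compound 3 by propanoylamino in place of methoxy on a saturated chain carbon bound to a saturated ring carbon. Both measured replacements of the 4-ethylpiperazin-1-yl group, a cyclic imide and a methoxy, moved the read-out to the limit, so another neutral, uncharged group at this place is expected to leave the value near or at the limit. For compound 4 the expected step is a number no higher from compound 3 to compound 4 (the limit leaves the size open), that is, none beyond the scatter, and the estimate is 400 ug/mL with a range from 150 ug/mL to 1000 ug/mL.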

Compound 4, half-maximal inhibitory concentration: 204 ug/mL
The estimate for compound 4 lay 2.0-fold (0.29 log units) above the measured number; measured number inside the range.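

In this assay, compound 4 shows that replacing 4-ethylpiperazin-1-yl on this saturated chain carbon can give a readable number rather than a limit. The change gives a 2.1-fold higher number from compound 1 to compound 4 (0.31 log units; beyond the scatter), so removing the 4-ethylpiperazin-1-yl group does not by itself carry the read-out to the limit. Against the two limit compounds, the data give only an at least 1.9-fold lower number from compound 3 to compound 4 (0.29 log units; that floor lies within the scatter) and an at least 1.9-fold lower number from compound 2 to compound 4 (0.29 log units; that floor lies within the scatter), and neither floor goes beyond the scatter, so the true size of these steps stays unknown because of this: the limit of > 400 ug/mL in this assay, at which 2 of the 4 values shown sit.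

As far as these compounds go, whether a plain amine, a carboxylic acid or a longer acyl chain at this place would fall nearer compound 1 or compound 4 stays open. Also open, from the compounds shown here alone, is whether the hydrogen-bond donor that propanoylamino brings and methoxy lacks plays any part in the value of compound 4.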